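Ethynyl to thiophen-2-yl exchange on the shared core

The compounds below may be only part of what the source reports. "The series", "measured", "known", "first", "only" and "open" are said of these compounds alone.

Measured so far:
Compound 1, `C#Cc1cn([C@@H]2O[C@H](CO)[C@@H](O)[C@H]2O)c2ncnc(C)c12`, gives 19200 nM in a functional assay on A549 cells (Homo sapiens), read by MTT assay, with a stated time of 72 h; a lower number here means a stronger inhibitor, a higher number a weaker inhibitor.
Compound 2, `C#Cc1cn([C@@H]2O[C@H](CO)[C@@H](O)[C@H]2O)c2ncnc(N(C)C)c12`, gives 390 nM in this assay.

Compound 2 holds the lowest of the two numbers in this assay; its nearest neighbour is compound 1, separated by a 49-fold lower number from compound 1 to compound 2 (1.69 log units; beyond the scatter), a large step from dimethylamino in place of methyl on an aromatic carbon.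

Compound 3, `CN(C)c1ncnc2c1c(-c1cccs1)cn2[C@@H]1O[C@H](CO)[C@@H](O)[C@H]1O`, is not yet measured. It differs from compound 2 by thiophen-2-yl in place of ethynyl on an aromatic carbon, the exchange sitting on an aromatic carbon of the five-membered aromatic ring with 1 nitrogen, part of the fused system of two rings. Among the measured compounds shown here, the one measured step, a 49-fold lower number from compound 1 to compound 2 (1.69 log units; beyond the scatter), concerns a different place on the core and a different pair of groups, so it does not bear on this exchange. For the measured compounds named here, no measured pair varies the group at this aromatic carbon, and the direction of the change is open on the present numbers.

Going by the values given here, with no precedent, the expected step of a 1.5-fold higher number from compound 2 to compound 3 (0.19 log units; within the scatter) is kept modest, and a wide range is set. Compound 3 is estimated at 600 nM, from 150 nM to 2500 nM.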

Compound 3, half-maximal inhibitory concentration: > 20000 nM
Compound 3 gave a limit, no number (the forecaster's own chance of this, stated with the estimate: 5%); middle value at least 33-fold (1.52 log units) away from the limit.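

This aromatic carbon of the five-membered aromatic ring now has its first reading, and it is not indifferent to the group it carries: thiophen-2-yl in place of ethynyl gives an at least 51-fold higher number from compound 2 to compound 3 (1.70 log units; beyond the scatter) in this assay. The dimethylamino group that sets compound 2 apart from compound 1 is present in compound 3 as well, so keeping it does not preserve the activity of compound 2 through this exchange. Compound 3 is recorded only as a limit of the assay and not as a number, so the step is a minimum and its true size stays unknown: the limit of > 20000 nM in this assay, at which 1 of the 3 values shown sits.

Among the compounds shown here, the single pair does not separate the effect of a ring at this carbon from that of the thiophene sulfur or of the larger group as a whole, and a furan-2-yl ring, a phenyl ring or a longer alkyne chain at the same carbon would be needed to tell these apart. As far as these compounds go, whether the exchange acts in the same way with methyl in place of dimethylamino, as on the core of compound 1, also remains open.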